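Swapping a fluorine-rich group for butyl on an anilino core

The compounds below may be only part of what the source reports. "The series", "measured", "known", "first", "only" and "open" are said of these compounds alone.

Of the compounds shown here, three sharing one core have been measured in an assay on mitochondria from L6 cells (Rattus norvegicus) for activation, with a stated time of 90 min; on this read-out lower numbers stand for an effect already at smaller amounts and higher numbers for an effect only at larger amounts of compound. Compound 1 `Cc1cc(Nc2nc3nonc3nc2O)ccc1OCC(F)(F)F` gives 7000 nM. Compound 2 `Oc1nc2nonc2nc1Nc1cccc(S(F)(F)(F)(F)F)c1` gives 3700 nM in this assay. Compound 3 `Oc1nc2nonc2nc1Nc1ccc(S(F)(F)(F)(F)F)cc1` gives 3900 nM in this assay, the second highest of the three numbers; its nearest neighbour is compound 2, whose number differs from it only within the usual scatter, and even the furthest, compound 1, lies within that scatter, so the three values show no separation that can be read as a real difference.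

Compound 4 `CCCCc1ccc(Nc2nc3nonc3nc2O)cc1` has not yet been measured in this assay. It differs from compound 3 in one place: a group of 4 heavy atoms (4 carbon; no ring) in place of a group of 6 heavy atoms (5 fluorine, 1 sulfur; no ring), on an aromatic carbon. The incoming butyl sits para to a large group, where the sulfur-and-fluorine group stood before.

Among the compounds with values here, no step between measured compounds is available to guide this change. Since the three measured compounds, with quite different groups on that ring, all fall within the scatter of one another, the step from compound 3 to compound 4 is expected to be small, a 1.2-fold higher number from compound 3 to compound 4 (0.06 log units; within the scatter), with no direction that can be called beyond the scatter. Compound 4 is therefore estimated at 4500 nM in this assay, within a range from 1500 nM to 14000 nM.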

Compound 4, half-maximal effective concentration: 2100 nM
Estimate against measurement, compound 4: 2.1-fold (0.33 log units) above, within the range that was stated.
By their numbers in this assay, from the lowest: compounds 4, 2, 3 and 1 (each within the scatter of the next, the first and the last beyond it).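

In this assay, putting butyl in place of the group of five fluorines and one sulfur gives a 1.9-fold lower number from compound 3 to compound 4 (0.27 log units; within the scatter) and so stays inside the usual scatter. Within the data shown here, this is the only direct comparison at this place on the ring, and it shows that a chain of carbon alone and a group with no carbon at all read alike here, even though they share little beyond having no hydrogen-bond donors or acceptors. No measurement shown bears on the reason for this result.

Still open, on these data alone, is whether a longer chain such as octyl, an amine or a carboxylic acid at this same place would move the number beyond the scatter. Changes elsewhere on the shared core also remain untested by this comparison.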